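The compounds below may be only part of what the source reports. "The series", "measured", "known", "first", "only" and "open" are said of these compounds alone.

Measured compounds:
- compound 1 `O=S(=O)(Nc1ccc(-c2nc3cc(NS(=O)(=O)c4ccccc4O)ccc3o2)cc1)c1ccccc1O` — 18000 nM
- compound 2 `Cc1ccccc1S(=O)(=O)Nc1ccc(-c2nc3ccccc3o2)cc1` — 85000 nM

Of the compounds shown here, two have been measured in an assay on cells for inhibition of HSP60/HSP10 (Homo sapiens), with a stated time of 60 min; on this read-out lower numbers stand for stronger inhibition and higher numbers for weaker inhibition. Compound 1 gives 18000 nM in this assay, and compound 2 gives 85000 nM, the higher of the two numbers; the two values are separated by a gap that lies beyond the usual scatter, with compound 2 the weaker of the pair. Compound 3 `O=S(=O)(Nc1ccc(-c2nc3ccccc3o2)cc1)c1ccc(O)cc1` has not been measured. It differs from compound 2 in one place: 4-hydroxyphenyl in place of 2-methylphenyl on a sulfonyl sulfur. Within the data shown here, no measured pair shows this same change, so the size of the effect rests on the two values alone. Compound 3 is estimated to sit at a somewhat lower number than compound 2, a step of a 1.9-fold lower number from compound 2 to compound 3 (0.28 log units; within the scatter), which may not exceed the scatter. In this assay compound 3 is therefore expected to give about 45000 nM, with a range from 12000 nM to 150000 nM.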

Compound 3, half-maximal inhibitory concentration: 78000 nM
Estimate against measurement, compound 3: 1.7-fold (0.24 log units) below; low and high end bracket the measured number.
By their numbers in this assay, from the lowest: compound 1; then compounds 3 and 2 (each within the scatter of the next).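

In this assay, 4-hydroxyphenyl in place of 2-methylphenyl on a sulfonyl sulfur gives a 1.1-fold lower number from compound 2 to compound 3 (0.04 log units; within the scatter), so this first pair differing in one place shows no change that can be told from the scatter. At this position, the hydrogen-bond donor and acceptor counted for 4-hydroxyphenyl, and absent from 2-methylphenyl, come with no separable difference in this read-out. Nothing available bears on why the two groups cannot be told apart.

Compound 1 differs from the other two compounds in more than one place, so the shown compounds do not tie its value to any single feature. On these data alone, it also remains open whether an amine or a carboxylic acid on the phenyl ring at this sulfonyl sulfur would produce a step beyond the scatter.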